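Dropping a Fluoro from the Core of Compound 2

The source may report more compounds than this note shows. Statements on the series, on what has been measured and on what is new or still open speak of the compounds shown alone.

Of the compounds shown here, three built on a shared core have been measured. In an assay on HeLa cells for displacement of a labelled ligand from 5-hydroxytryptamine receptor 6 (Homo sapiens), with a stated time of 2 h (on this read-out higher numbers stand for weaker inhibition and lower numbers for stronger inhibition), compound 1 `O=S(=O)(c1cccc(F)c1)c1cn(C2CCCNC2)c2ccc(F)cc12` gives 4 nM. Compound 2 `O=S(=O)(c1cccc(F)c1)c1cn(C2CCNC2)c2cccc(F)c12` gives 18 nM in this assay, and compound 3 `CCN1CCCC(n2cc(S(=O)(=O)c3cccc(F)c3)c3cc(OC)ccc32)C1` gives 16 nM. Compound 2 thus carries the highest number of the three; its value and that of compound 3 sit within the usual scatter of each other, so the two cannot be told apart, while compound 1 lies beyond the scatter with the lower number.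

Compound 4 `O=S(=O)(c1cccc(F)c1)c1cn(C2CCNC2)c2ccccc12` has not been measured. It differs from compound 2 in one place: hydrogen in place of fluoro on an aromatic carbon. The fluoro leaves the aromatic carbon of the six-membered aromatic ring of carbon only, part of the fused system of two rings, and a hydrogen enters in its stead. Going by the values given here, no pair among the measured compounds differs by only this change, so there is no directly comparable step to lean on. With one atom removed and nothing else altered, the step of a 1.4-fold higher number from compound 2 to compound 4 (0.14 log units; within the scatter) in this assay is expected to stay within the scatter, perhaps drifting toward a higher number. For compound 4 the estimate is 25 nM, with a plausible range from 8 nM to 80 nM.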

Compound 4, inhibition constant: 4.7 nM
Estimate against measurement, compound 4: 5.3-fold (0.73 log units) above, outside the stated range (below it).
By their numbers in this assay, from the lowest: compounds 1 and 4 (each within the scatter of the next); then compounds 3 and 2 (each within the scatter of the next).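

In this assay, replacing the fluoro with hydrogen on this aromatic carbon of the core gives a 3.8-fold lower number from compound 2 to compound 4 (0.58 log units; beyond the scatter). Going by these compounds alone, this is the first step where only one place changes, so it can be read directly: the position is not indifferent, as a single atom exchange with nothing else altered moves the number by more than repeat measurements would explain, and the fluoro is not needed here for strong inhibition, since the compound with hydrogen has the lower number and lower numbers stand for stronger inhibition. The result describes only what happens to the number, and no accompanying measurement shows what lies behind a step of this size.

Going by these compounds, with only hydrogen and fluoro compared at this position, it remains open whether a chloro, a methyl or a nitrile on the same aromatic carbon would give a number closer to that of compound 2 or to that of compound 4. On these data alone, it is also open whether exchanging fluoro for hydrogen on compound 1 would give a step of similar size and direction, so this single step cannot yet be treated as a rule for the whole series.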